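A few compounds are considered here, and "the series" means these few. Any claim that something is new, unique, unknown or untested is made for them only; others in the source may bear on it.

Of the compounds shown here, three have been measured in a functional assay on MCF7 cells (Homo sapiens) for antiproliferative activity; on this read-out higher numbers stand for weaker inhibition and lower numbers for stronger inhibition. Compound 1 `COC(CNc1ccccc1CO)n1cc(F)c(=O)[nH]c1=O` gives 36000 nM. Compound 3 `Clc1nc(Cl)c2c(ncn2C2COc3ccccc3CO2)n1` gives 1250 nM. Compound 2 `O=[N+]([O-])c1ccc(S(=O)(=O)N2CC(n3cnc4ncnc(O)c43)OCc3ccccc32)cc1` reaches only the limit of the assay, > 100000 nM, so no number is known for it. The limit of > 100000 nM in this assay, at which 1 of the 3 values shown sits, is where compound 2 stands; of the three values shown, it is the one that is a limit rather than a number.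

Compound 4 `O=[N+]([O-])c1ccc(S(=O)(=O)N2CC(n3cnc4c(Cl)ncnc43)OCc3ccccc32)cc1` differs from compound 2 in one place: a group of 10 heavy atoms (5 carbon, 4 nitrogen, 1 chlorine; one five-membered aromatic ring with 2 hetero atoms, one six-membered aromatic ring with 2 hetero atoms) in place of a group of 10 heavy atoms (5 carbon, 4 nitrogen, 1 oxygen; one five-membered aromatic ring with 2 hetero atoms, one six-membered aromatic ring with 2 hetero atoms), on a saturated ring carbon. Because the value of compound 2 is a limit, the size of the step from compound 2 to compound 4 cannot be tied to a measured number; it can only be read as a change toward stronger or weaker inhibition from a starting point at the limit. Compound 3, which also carries chlorine on its fused aromatic rings, gives 1250 nM, which points toward a number rather than a limit for compound 4. For compound 4 the estimated value is 20000 nM, with a range from 3000 nM to 100000 nM, and this means an expected step of an at least 5.0-fold lower number from compound 2 to compound 4 (0.69 log units; beyond the scatter).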

Compound 4, half-maximal inhibitory concentration: 2730 nM
Compound 4: middle estimate off by 7.3-fold (0.86 log units), on the high side; the measured number lies below the stated range.
By their numbers in this assay, from the lowest: compound 3; then compound 4; then compound 1. At a limit, above all of these: compound 2.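

Compounds 2 and 4 are the first pair shown that differ in one place, so they give the first direct reading of a change on this saturated ring carbon of the seven-membered ring. In this assay, replacing the fused aromatic group that holds one oxygen with the one that holds one chlorine, while the rest of the molecule stays the same, gives an at least 36-fold lower number from compound 2 to compound 4 (1.56 log units; beyond the scatter). The true size of this large step remains unknown, as the value of compound 2 is a limit and not a number: the limit of > 100000 nM in this assay, at which 1 of the 4 values shown sits.

The change also takes away the hydrogen-bond donor of the leaving group, and this single pair cannot separate that loss from the arrival of the chlorine. Compounds carrying an amine or a methoxy group where the chlorine sits in compound 4 could help to tell the two apart.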